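Arylidene variation on the shared core: compound 3 outlook

A few compounds are considered here, and "the series" means these few. Any claim that something is new, unique, unknown or untested is made for them only; others in the source may bear on it.

Compound 1 `O=C1N/C(=N/c2csc(-c3ccc(Cl)cc3)c2)S/C1=C\c1ccc2ccccc2c1` gives 1800 nM in a functional assay on MDA-MB-231 cells (Homo sapiens) for cytotoxicity, read by MTT assay, with a stated time of 72 h; a lower number here means a stronger inhibitor, a higher number a weaker inhibitor. Among the measured compounds shown here, compound 2 `O=C1N/C(=N/c2csc(-c3ccc(Cl)cc3)c2)S/C1=C\c1ccccn1` gives 10900 nM in this assay, the highest number of the two measured so far, and its only neighbour is compound 1, reached by the step of a 6.1-fold higher number from compound 1 to compound 2 (0.78 log units; beyond the scatter). Compound 3 `COc1ccc(/C=C2\S/C(=N\c3csc(-c4ccc(Cl)cc4)c3)NC2=O)cc1OC` is not yet measured; it differs from compound 2 by 3,4-dimethoxyphenyl in place of pyridin-2-yl on a double-bonded chain carbon bound to a double-bonded ring carbon. For the measured compounds named here, the one step that bears on this position is a 6.1-fold higher number from compound 1 to compound 2 (0.78 log units; beyond the scatter), which shows that the group on the double-bonded chain carbon shifts the number beyond the scatter and that the carbocyclic aryl of compound 1 gave the lower number. Compound 3 carries a carbocyclic aryl again, so a decrease in this assay is expected, of a size a 3.1-fold lower number from compound 2 to compound 3 (0.49 log units; beyond the scatter), short of a full return to compound 1. Compound 3 is therefore estimated at 3500 nM, within 1200 nM to 10000 nM.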

Compound 3, half-maximal inhibitory concentration: 1900 nM
Compound 3: middle estimate off by 1.8-fold (0.27 log units), on the high side; low and high end bracket the measured number.
By their numbers in this assay, from the lowest: compounds 1 and 3 (each within the scatter of the next); then compound 2.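

Replacing pyridin-2-yl with 3,4-dimethoxyphenyl on the double-bonded chain carbon gives a 5.7-fold lower number from compound 2 to compound 3 (0.76 log units; beyond the scatter) in this assay and shows that the number at this position is not tied to the naphthalen-2-yl of compound 1 alone. Exchanging naphthalen-2-yl for 3,4-dimethoxyphenyl gives a 1.1-fold higher number from compound 1 to compound 3 (0.02 log units; within the scatter) in this assay and so leaves these two carbon-only aromatic groups unseparated, with compound 2 alone apart from them among the three compounds. Nothing on hand accounts for these differences.

The compounds shown leave open whether either methoxy group of compound 3 is needed for its number, or whether an unsubstituted phenyl would read the same. Also open, from the compounds shown here alone, is how a phenyl carrying a carboxylic acid or an amine would read at this position.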